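This account rests on a few compounds, and the source may have more. Where it says the series, first, only, none or still open, it means among the compounds named here.

In a functional assay on HepG2 cells (Homo sapiens) for cytotoxicity, read by MTT assay, with a stated time of 48 h (a higher number here means a weaker inhibitor, a lower number a stronger inhibitor), compound 1 `COc1cc(-c2nnc3n2NC(c2ccco2)C(C(=O)c2ccc(F)c(F)c2)S3)cc(OC)c1OC` gives 52400 nM. Compound 2 `COc1cc(-c2nnc3n2NC(c2cccs2)C(C(=O)c2ccc(F)cc2)S3)cc(OC)c1OC` gives 54200 nM, and the two values sit within the scatter of each other, so neither can be set apart from the other. Compound 3 `COc1ccc(C(=O)C2Sc3nnc(-c4cc(OC)c(OC)c(OC)c4)n3NC2c2ccco2)cc1` differs from compound 1 in one place: 4-methoxyphenyl in place of 3,4-difluorophenyl on a carbonyl carbon. Within the data shown here, no measured pair shows this change, so nothing about its effect is known here. Among the measured compounds shown here, with only two close values to go on, the step of a 1.0-fold lower number from compound 1 to compound 3 (0.02 log units; within the scatter) is expected to be small, no larger than the scatter. The expected value for compound 3 is therefore 50000 nM, estimated to lie between 20000 nM and 150000 nM.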

Compound 3, half-maximal inhibitory concentration: > 100000 nM
Compound 3 ended at the assay's limit; the forecaster's own chance of this, stated with the estimate: 20%; at least 2.0-fold (0.30 log units) between middle value and limit.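

The value of compound 3 is a limit of the assay and not a number: the limit of > 100000 nM in this assay, at which 1 of the 3 values shown sits. At this position, on a carbonyl carbon, 4-methoxyphenyl in place of 3,4-difluorophenyl gives an at least 1.9-fold higher number from compound 1 to compound 3 (0.28 log units; that floor lies within the scatter). This first reading at the position shows no gain in inhibition from the change, but it cannot establish a real loss.

This single change does not separate losing the two fluorines from gaining the methoxy group. As far as these compounds go, how a plain phenyl, or a phenyl carrying an amine or a carboxylic acid, would behave here remains open.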